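Swapping an Oxazole for a Methylphenyl: Expected Cell Toxicity

The source may hold more compounds than are shown below. What is called first, only, known or untested is meant among the compounds shown, and "the series" means these compounds.

Compound 1 `COc1ccc(-c2cnc(NC(=O)c3ccc([N+](=O)[O-])cc3)n2C)cc1` and compound 2 `COc1ccc(-c2cnc(NC(=O)c3cnco3)n2C)cc1` share one core and differ only in the group attached to the carbonyl carbon of the amide. Both were tested in a toxicity assay on THP-1 cells (Homo sapiens) for inhibition; on this read-out lower numbers stand for higher toxicity in this test and higher numbers for lower toxicity in this test. In this assay compound 1 returns a limit, > 100000 nM, and not a number. In this assay compound 2 likewise returns only a limit, > 100000 nM. Compound 2 therefore stands exactly where the other value stands, namely at the limit of > 100000 nM in this assay, at which 2 of the 2 values shown sit. Among the measured compounds shown here, from two limits no step between measured compounds can be read.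

Compound 3 `COc1ccc(-c2cnc(NC(=O)c3ccc(C)cc3)n2C)cc1` has not been measured yet. It differs from compound 2 in one place: 4-methylphenyl in place of 1,3-oxazol-5-yl on a carbonyl carbon. Because both values shown sit at the limit of > 100000 nM in this assay, at which 2 of the 2 values shown sit, no step beyond the scatter is expected in this assay from compound 2 to compound 3, and compound 3 is expected most likely to return only a limit again. For compound 3 the estimated value in this assay is 100000 nM, with an expected range from 30000 nM to 300000 nM. The expected step of a number no higher from compound 2 to compound 3 (the limit leaves the size open) is essentially none.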

Compound 3, half-maximal cytotoxic concentration: > 100000 nM
Compound 3 was reported as a limit; the forecaster's own chance of this, stated with the estimate: 80%; the middle value lies on the limit itself.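

In this assay compound 3 gives > 100000 nM, which is a limit and not a number. Compound 1 and compound 2 also returned only limits, so no step to compound 3 can be read from either of them: the limit of > 100000 nM in this assay, at which 3 of the 3 values shown sit.

The compounds shown leave open whether changing the group on the carbonyl carbon alters toxicity in this assay at all.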